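The compounds below may be only part of what the source reports. "The series", "measured", "known", "first", "only" and "open" are said of these compounds alone.

Working notes on the hydrazone series.

The shared core carries a pentyl-substituted hydrazone aryl group that is the only point varied here. Compound 1 `Cn1c(=O)c(=O)n(C2CCCC2)c2nc(N/N=C/c3ccc(O)cc3)ncc21` bears a 4-hydroxyphenyl; in a functional assay on A549 cells (Homo sapiens) for antiproliferative activity, read by MTT assay (on this read-out higher numbers stand for weaker inhibition and lower numbers for stronger inhibition), compound 1 gives only a limit, > 100000 nM, which marks the limit of > 100000 nM in this assay, at which 1 of the 3 values shown sits, and is not a number. Compound 2 `COc1cccc(/C=N/Nc2ncc3c(n2)n(C2CCCC2)c(=O)c(=O)n3C)c1` carries a 3-methoxyphenyl and in this assay compound 2 gives 27400 nM. Within the data shown here, compound 3 `Cn1c(=O)c(=O)n(C2CCCC2)c2nc(N/N=C/c3ccc(F)cc3Cl)ncc21` carries a 2-chloro-4-fluorophenyl and in this assay compound 3 gives 11000 nM, the lowest of the two numbers known; the step of a 2.5-fold lower number from compound 2 to compound 3 (0.40 log units; beyond the scatter) separates it from its nearest neighbour, and the step of an at least 9.0-fold lower number from compound 1 to compound 3 (0.95 log units; beyond the scatter) separates it from the limit of compound 1.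

Compound 4 `Cn1c(=O)c(=O)n(C2CCCC2)c2nc(N/N=C/c3cc([N+](=O)[O-])ccc3Cl)ncc21` differs from compound 3 only at the hydrazone aryl: 2-chloro-5-nitrophenyl in place of 2-chloro-4-fluorophenyl on a carbon with a double bond to nitrogen. The measured steps that bear on this are an at least 9.0-fold lower number from compound 1 to compound 3 (0.95 log units; beyond the scatter) and a 2.5-fold lower number from compound 2 to compound 3 (0.40 log units; beyond the scatter), both changes of the same aryl group, both modest, both downward toward compound 3. Both steps moved toward a halogenated aryl, and compound 4 keeps the chlorine of compound 3 while swapping the fluorine for a nitro group. Among the measured compounds shown here, no measured step isolates this swap, so the expectation for this assay is a step of a 1.2-fold lower number from compound 3 to compound 4 (0.09 log units; within the scatter), not expected to exceed the scatter. Compound 4 is therefore estimated at 9000 nM, with a range from 3000 nM to 30000 nM.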

Compound 4, half-maximal inhibitory concentration: 8780 nM
Estimate against measurement, compound 4: 1.0-fold (0.01 log units) above, and the stated range covers the measured number.
By their numbers in this assay, from the lowest: compounds 4 and 3 (each within the scatter of the next); then compound 2. At a limit, above all of these: compound 1.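

In this assay, a 1.3-fold lower number from compound 3 to compound 4 (0.10 log units; within the scatter), so with the chlorine kept, the 2-chloro-5-nitrophenyl and 2-chloro-4-fluorophenyl groups on the carbon with a double bond to nitrogen cannot be told apart, even though the entering group is larger and adds hydrogen-bond acceptors. The earlier steps toward compound 3 could be read as tied to its fluorine, but compound 4 has none and still shows a 3.1-fold lower number from compound 2 to compound 4 (0.49 log units; beyond the scatter) and an at least 11-fold lower number from compound 1 to compound 4 (1.05 log units; beyond the scatter), so among the four compounds shown, both 2-chloro aryl groups stand beyond the scatter from the 3-methoxyphenyl and 4-hydroxyphenyl groups. The last of these steps starts from a limit and not a number, the one held by compound 1: the limit of > 100000 nM in this assay, at which 1 of the 4 values shown sits.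

Whether the chlorine alone accounts for these steps remains open, as both compounds that carry it also have a second group on the ring, and a 2-chlorophenyl group would test this directly. From the compounds shown here alone, how an amine or a carboxylic acid in place of the nitro group would read in this assay is also open, as is any change away from the hydrazone aryl group on the shared core.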